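This account rests on a few compounds, and the source may have more. Where it says the series, first, only, none or still open, it means among the compounds named here.

Among the compounds with values here, in a functional assay on OVCAR-5 cells (Homo sapiens) for inhibition, with a stated time of 48 h, tested at 50 uM (on this read-out lower numbers stand for less inhibition of growth and higher numbers for more inhibition of growth at the one concentration tested), only two compounds have numbers so far. Compound 1 (`C=C[C@@](C)(/C=C/c1ccc(OC(=O)CCCCC)cc1)CCC=C(C)C`) gives 13%, and compound 2 (`C=C[C@@](C)(/C=C/c1ccc(O)cc1)CC/C=C(/C)C=O`) gives 22%. These two values lie within the usual scatter of each other, so compound 2 stands level with compound 1 and the pair cannot be ranked.

The next compound is compound 3 (`C=C[C@@](C)(/C=C/c1ccc(O)cc1)CCC1OC1(C)C`), which differs from compound 2 in one place: 3,3-dimethyloxiran-2-yl in place of 2-formylprop-1-en-1-yl on a saturated chain carbon, three bonds along the chain from two double-bonded chain carbons. In plain words, 3,3-dimethyloxiran-2-yl takes the place of 2-formylprop-1-en-1-yl on a saturated chain carbon.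

Within the data shown here, no two measured compounds differ in one place only, so the data offer no measured step to use as a guide for this swap. With no evidence for either direction, no step beyond the scatter is expected in this assay, and compound 2, at 22%, serves as the starting point. The expected change is small, a number 2 percentage points lower from compound 2 to compound 3 (within the scatter). For compound 3, the estimated value is 20%, with an expected range of 8% to 35%.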

Compound 3, percent growth inhibition at one concentration: 12%
The estimate for compound 3 lay 8 percentage points above the measured number, and the stated range covers the measured number.
By their numbers in this assay, from the lowest: compounds 3, 1 and 2 (each within the scatter of the next).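

Within the data shown here, the swap of 2-formylprop-1-en-1-yl for 3,3-dimethyloxiran-2-yl, on a saturated chain carbon, three bonds along the chain from two double-bonded chain carbons, is the first single-place change that can be read in this assay, and it gives a number 10 percentage points lower from compound 2 to compound 3 (within the scatter). At this position, then, an open-chain group carrying a formyl and a group carrying a three-membered oxygen ring, with the same count of heavy atoms, cannot be told apart at the one concentration tested, so the formyl group and its double bond can be exchanged for this ring without a step beyond the scatter. No measurement shown here bears on this result, and the step offers no explanation of its own.

From the compounds shown here alone, whether a carboxylic acid or a primary amine in this place, or a longer chain ending in either, would give a number beyond the scatter of compound 2 remains open. A single-concentration read-out also leaves open how compound 2 and compound 3 would compare at other concentrations.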